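Swapping 2-hydroxyethyl for 3-hydroxycyclobutyl on a saturated ring

A few compounds are considered here, and "the series" means these few. Any claim that something is new, unique, unknown or untested is made for them only; others in the source may bear on it.

Results in an ADME assay on Caco-2 cells (Homo sapiens) for permeability, read by LC-MS, in the apical to basolateral direction, with a stated time of 2 h (on this read-out higher numbers stand for higher permeability and lower numbers for lower permeability), for the compounds tested so far
- compound 1 `COc1cc(C(=O)N2CCC(O)C(C)C2)cc2nc(NCc3cc(Cl)ccc3O)oc12` gives "not determined" (no result reported)
- compound 2 `COc1cc(C(=O)N2CCC(O)C(C)C2)cn2nc(NCc3cccc(Cl)c3)nc12` gives 71 nm/s
- compound 3 `COc1cc(C(=O)N2CC(C)OCC2CCO)cn2nc(NCc3cccc(Cl)c3)nc12` gives "not determined" (no result reported)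

Compound 3 has no number to start from, since its entry reads "not determined" (no result reported) in this assay. Compound 4 `COc1cc(C(=O)N2CC(C)OCC2C2CC(O)C2)cn2nc(NCc3cccc(Cl)c3)nc12` is still to be measured. The change is 3-hydroxycyclobutyl in place of 2-hydroxyethyl on a saturated ring carbon, with 3-hydroxycyclobutyl in place of 2-hydroxyethyl on a saturated ring carbon. Among the compounds with values here, no measured pair shows what this change does, so no step beyond the usual scatter is expected in this assay, in either direction. Within the data shown here, the only number to lean on is that of compound 2, at 71 nm/s, which shares its core with compound 3. For compound 4 the estimated value is 60 nm/s (20 nm/s to 160 nm/s).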

Compound 4, apparent permeability: 72 nm/s
Estimate against measurement, compound 4: 1.2-fold (0.08 log units) below, within the range that was stated.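

In this assay, within the data shown here, compound 3 has no single number, so no step to compound 4 can be read. No supporting evidence bears on this result. The compounds shown leave open what 3-hydroxycyclobutyl in place of 2-hydroxyethyl does in this assay.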